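The compounds below may be only part of what the source reports. "The series", "measured", "known", "first", "only" and "open" are said of these compounds alone.

Compound 3 `CC(C(=O)NCc1ccc(C(F)(F)F)nc1N1CCC(Cc2ccc(F)c(F)c2)CC1)c1ccc(NS(C)(=O)=O)c(F)c1` gives 0.2 nM in a functional assay on CHO-K1 cells for antagonist activity at transient receptor potential cation channel subfamily V member 1 (Homo sapiens), read by FLIPR; on this read-out higher numbers stand for weaker inhibition and lower numbers for stronger inhibition; that is the lowest of the three numbers, yet within the scatter of compound 1 `CC1CCCN1c1nc(C(F)(F)F)ccc1CNC(=O)[C@@H](C)c1ccc(NS(C)(=O)=O)c(F)c1` at 0.3 nM and of compound 2 `C[C@H](C(=O)NCc1ccc(C(F)(F)F)nc1N1CCC(c2ccccc2)CC1)c1ccc(NS(C)(=O)=O)c(F)c1` at 0.3 nM, so no order among them can be read. Compound 4 `CC(C(=O)NCc1ccc(C(F)(F)F)nc1N1CCC(OC(=O)C(C)(C)C)CC1)c1ccc(NS(C)(=O)=O)c(F)c1` differs from compound 3 by ((tert-butyl)carbonyl)oxy in place of 3,4-difluorobenzyl on a saturated ring carbon. For the measured compounds named here, the only step measured at this part of the core is no change at the digits printed from compound 1 to compound 2 (within the scatter), and compounds 2 and 3 show values within scatter of each other, so variation of the group on the saturated ring has so far cost nothing. Going by the values given here, the entering group carries two hydrogen-bond acceptors where none stood, which no measured step covers, so a modest loss is expected, a 5.0-fold higher number from compound 3 to compound 4 (0.70 log units; beyond the scatter), giving compound 4 an estimated 1 nM with a range of 0.3 nM to 4 nM.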

Compound 4, inhibition constant: 2 nM
For compound 4 the middle estimate is 2.0-fold (0.30 log units) below the measured one; low and high end bracket the measured number.
By their numbers in this assay, from the lowest: compounds 3, 1 and 2 (each within the scatter of the next); then compound 4.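

In this assay, for the compounds shown here, a 10-fold higher number from compound 3 to compound 4 (1.00 log units; beyond the scatter) is the first step beyond the scatter at this part of the core, so the group on the saturated ring carbon can matter after all. The loss remains modest: with no ring and 2 hydrogen-bond acceptors in the group, compound 4 still gives 2 nM. No measurement at hand accounts for this step.

The loss of the aromatic ring and the arrival of the carbonyl and oxygen change together here, so neither can be assigned the loss. As far as these compounds go, a hydroxyl, a primary amine or a carboxylic acid on the same ring carbon remains open.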